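This account rests on a few compounds, and the source may have more. Where it says the series, first, only, none or still open, it means among the compounds named here.

In an ADME assay on HepG2 cells (Homo sapiens) for cytotoxicity, read by resazurin assay, with a stated time of 24 h (a higher number here means a weaker inhibitor, a lower number a stronger inhibitor), the three measured compounds stand as follows.

Compound 1 `COc1ccc2c(=O)c(-c3ccc(Oc4ccc(OC(F)(F)F)cc4)cc3)c(C)[nH]c2c1` gives > 10000 nM, which is a limit of the assay rather than a number.
Compound 2 `Cc1[nH]c2ccc(Cl)cc2c(=O)c1-c1ccc(Oc2ccc(OC(F)(F)F)cc2)cc1` gives > 10000 nM, likewise a limit.
Compound 3 `COc1cc2[nH]c(C)c(-c3ccc(Oc4ccc(OC(F)(F)F)cc4)cn3)c(=O)c2cc1Cl` gives > 10000 nM, likewise a limit.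

Compound 1 therefore stands exactly where the other two stand: all of them sit at the limit of > 10000 nM in this assay, at which 3 of the 3 values shown sit, and no ordering among them can be read from these values. Going by the values given here, no step between measured compounds that differ in one place is available, so the change from compound 1 to compound 4 must be judged on its own. Compound 4 `COc1cc2[nH]c(C)c(-c3ccc(Oc4ccc(OC(F)(F)F)cc4)cc3)c(=O)c2cc1F` differs from compound 1 by fluoro in place of hydrogen on an aromatic carbon. In this assay no step beyond the usual scatter is expected for this change, in either direction, because every value shown sits at the limit of > 10000 nM in this assay, at which 3 of the 3 values shown sit. Compound 4 is accordingly expected to give about 15000 nM in this assay, within a range of 10000 nM to 40000 nM, and most probably to be reported again only as a limit. The step that the limit leaves unreadable from compound 1 to compound 4 is thus estimated as essentially none.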

Compound 4, half-maximal inhibitory concentration: > 10000 nM
Compound 4: no number, only a limit; the forecaster's own chance of this, stated with the estimate: 90%; the middle value does not contradict the limit.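

In this assay compound 4 gives > 10000 nM as a limit. Going by these compounds alone, no step from compound 1 to compound 4 can be read, because both values are limits: the limit of > 10000 nM in this assay, at which 4 of the 4 values shown sit. The compounds shown leave open what concentration, if any, would reach half-maximal inhibition for any of them in this assay as well as whether fluoro in place of hydrogen changes that concentration.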